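A few compounds are considered here, and "the series" means these few. Any claim that something is new, unique, unknown or untested is made for them only; others in the source may bear on it.

Three compounds share one core and differ only in the group on an aromatic carbon. Compound 1 `COc1cc(OC)c2c(=O)cc(C(=O)Nc3ccc(N4CCN(C)CC4)cc3)[nH]c2c1` carries a 4-methylpiperazin-1-yl group, compound 2 `COc1cc(OC)c2c(=O)cc(C(=O)Nc3ccc(Oc4ccc(F)cc4)cc3)[nH]c2c1` a 4-fluorophenoxy group, and compound 3 `COc1cc(OC)c2c(=O)cc(C(=O)Nc3ccc(Oc4cccnc4)cc3)[nH]c2c1` a (pyridin-3-yl)oxy group. In an ADME assay on BJ cells (Homo sapiens) for antiproliferative activity, with a stated time of 72 h (a lower number here means that less compound is needed, a higher number that more compound is needed for the effect), compound 1 gives only a limit, > 19800 nM. Compound 2 likewise gives a limit in this assay, > 50000 nM. Compound 3 also reaches only a limit, > 32100 nM. Each value sits at its own limit (the limit of > 19800 nM in this assay, at which 1 of the 3 values shown sits), (the limit of > 32100 nM in this assay, at which 1 of the 3 values shown sits), (the limit of > 50000 nM in this assay, at which 1 of the 3 values shown sits), so the measured steps cannot be read: a step that the two limits leave unreadable from compound 1 to compound 2, a step that the two limits leave unreadable from compound 1 to compound 3 and a step that the two limits leave unreadable from compound 2 to compound 3 are all of unreadable size. Compound 3 thus stands at a limit beside two other limits.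

Compound 4 `COc1cc(OC)c2c(=O)cc(C(=O)Nc3ccc(-n4cccc4)cc3)[nH]c2c1` is not yet measured. It differs from compound 3 in one place: 1H-pyrrol-1-yl in place of (pyridin-3-yl)oxy on an aromatic carbon. For the measured compounds named here, no measured step bears on this change with a readable size, and all three measured compounds sit at limits. Compound 4 is therefore expected to land near those limits, with a step that the limit leaves unreadable from compound 3 to compound 4 expected to stay within the scatter, and its estimated value in this assay is 40000 nM, in a range from 10000 nM to 100000 nM.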

Compound 4, half-maximal effective concentration: > 77000 nM
Compound 4 gave a limit, no number; the forecaster's own chance of this, stated with the estimate: 80%; middle value at least 1.9-fold (0.28 log units) away from the limit.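

In this assay compound 4 gives > 77000 nM, which is a limit and not a number. Its steps from compound 1, compound 2 and compound 3 cannot be read. The four compounds shown leave open what concentration of any of them gives the effect, and whether these groups differ at all.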